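A Larger Group on Compound 2

The source may report more compounds than this note shows. Statements on the series, on what has been measured and on what is new or still open speak of the compounds shown alone.

Compound 1 `O=c1sc2ccccc2n1CCCCCN1CCN(CCCCCn2c(=O)sc3ccccc32)CC1` gives 430 nM
Compound 2 `O=c1sc2ccccc2n1CCCCCCN1CCN(CCCn2c(=O)sc3ccccc32)CC1` gives 2400 nM

These two compounds have been measured in an assay on SW1353 cells (Homo sapiens) for inhibition, read by a luciferase reporter, with stated times of 30 min and 8 h; a higher number here means a weaker inhibitor, a lower number a stronger inhibitor. Compound 2 stands highest of the two, making it the weaker inhibitor, and its gap to compound 1 lies beyond the scatter. Compound 3 `O=c1sc2ccccc2n1CCCCCCN1CCN(CCCCCn2c(=O)sc3ccccc32)CC1`, not yet measured, departs from compound 2 in one place: a group of 12 heavy atoms (9 carbon, 1 nitrogen, 1 oxygen, 1 sulfur; one five-membered aromatic ring with 2 hetero atoms, one six-membered aromatic ring of carbon only) in place of a group of 10 heavy atoms (7 carbon, 1 nitrogen, 1 oxygen, 1 sulfur; one five-membered aromatic ring with 2 hetero atoms, one six-membered aromatic ring of carbon only), on a saturated chain carbon, three bonds along the chain from an amine nitrogen in a ring. The change falls on a saturated chain carbon, three bonds along the chain from an amine nitrogen in a ring. Among the measured compounds shown here, no measured step shows what such a change does, so the expectation is tentative: a lower number in this assay, by a step beyond the scatter, approaching compound 1 at 430 nM. The expected change is a 4.0-fold lower number from compound 2 to compound 3 (0.60 log units; beyond the scatter). For compound 3 the estimated half-maximal inhibitory concentration is 600 nM, with an expected range from 180 nM to 2000 nM.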

Compound 3, half-maximal inhibitory concentration: 1060 nM
For compound 3 the middle estimate is 1.8-fold (0.25 log units) below the measured one; measured number inside the range.
By their numbers in this assay, from the lowest: compound 1; then compound 3; then compound 2.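

In this assay, the group of 12 heavy atoms in place of the group of 10 heavy atoms, on a saturated chain carbon three bonds along the chain from an amine nitrogen in a ring, gives a 2.3-fold lower number from compound 2 to compound 3 (0.35 log units; beyond the scatter), so this position responds to the change, though only modestly. A second change, the group of 11 heavy atoms in place of the group of 10 heavy atoms, on a saturated chain carbon five bonds along the chain from an amine nitrogen in a ring, gives a 2.5-fold higher number from compound 1 to compound 3 (0.39 log units; beyond the scatter), so the two changes that add to a group move the number in opposite directions. No measurement here accounts for either step.

On these data alone, whether a longer chain at the first position would lower the number further remains open. So does the effect of a hydroxyl group on either chain.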